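Shifting Two Methoxy Groups: Expected Cytotoxicity of Compound 3

The source may report more compounds than this note shows. Statements on the series, on what has been measured and on what is new or still open speak of the compounds shown alone.

Compound 1, `COc1ccc(-c2csc(N/N=C(C)/C=C/c3ccc(OC)c(OC)c3)n2)cc1`: > 11000 nM in an ADME assay on THP-1 cells (Homo sapiens) for cytotoxicity, read by CellTiter-Glo, with a stated time of 3 days; on this read-out lower numbers stand for stronger inhibition and higher numbers for weaker inhibition (a limit)
Compound 2, `COc1ccc(/C=C/C(C)=N/Nc2nc(-c3ccc(OC)c(OC)c3)cs2)cc1OC`: 38000 nM in this assay

Among the measured compounds shown here, compound 2 gives the only number; compound 1 gives only a limit of the assay. The step that the limit leaves unreadable from compound 1 to compound 2 cannot be read, being set by the limit of > 11000 nM in this assay, at which 1 of the 2 values shown sits. Compound 3, `COc1ccc(/C=C/C(C)=N/Nc2nc(-c3c(OC)cccc3OC)cs2)cc1OC`, differs from compound 2 by 2,6-dimethoxyphenyl in place of 3,4-dimethoxyphenyl on an aromatic carbon. For the measured compounds named here, no measured step rearranges methoxy groups on that ring, so none bears on this change, and no step beyond the scatter is expected in this assay. Compound 3 is therefore expected at 38000 nM, between 15000 nM and 95000 nM. The expected step of no change at the digits printed from compound 2 to compound 3 (within the scatter) is within the scatter.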

Compound 3, half-maximal inhibitory concentration: > 11000 nM
Compound 3 gave a limit, no number; the forecaster's own chance of this, stated with the estimate: 30%; the middle value lies beyond the limit too.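

In this assay, among the compounds shown here, compound 3 gave only a limit, and no step to it from compound 1 or compound 2 can be read. Going by these compounds, whether 2,6-dimethoxyphenyl in place of 3,4-dimethoxyphenyl changes cytotoxicity at all stays open.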